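Series notes: benzyl removal on the saturated ring carbon

The source may hold more compounds than are shown below. What is called first, only, known or untested is meant among the compounds shown, and "the series" means these compounds.

Working notes on the series in a functional assay on the whole organism (Pleural cavity) for inhibition, with Rattus norvegicus as the target, at a dose of 25 mg/kg; on this read-out lower numbers stand for less inhibition and higher numbers for more inhibition at the one dose given (going by the name of the read-out). Compound 1 `CC1(C)C(=O)N(c2ccc(S(C)(=O)=O)cc2)c2ncccc21` gives 0% in this assay. Compound 3 `CC1(C)C(=O)N(Cc2ccc(Cl)cc2)c2ncccc21` gives 0%. For the measured compounds named here, compound 2 `CC1(Cc2ccccc2)C(=O)N(c2ccccc2)c2ncccc21` gives 0%, level with compound 1 and with compound 3 at the digits recorded; its nearest and furthest neighbours both sit within the scatter, so no compound stands apart from another. Going by the values given here, no pair of measured compounds differs in a single place, so no measured step is available. Compound 4 `CC1C(=O)N(c2ccccc2)c2ncccc21` is still to be measured in this assay. Relative to compound 2 the change is hydrogen in place of benzyl on a saturated ring carbon. With every recorded value flat at the digits shown and nothing pointing in either direction, no step beyond the scatter is expected in this assay. The expected step from compound 2 to compound 4 is no change at the digits printed from compound 2 to compound 4 (within the scatter). Compound 4 is estimated at 0%, with a range of -8% to 12%.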

Compound 4, a percentage reported as inhibition, in the whole organism at one dose (the size of the read-out at that dose, not a potency): 18%
The estimate for compound 4 lay 18 percentage points below the measured number; the whole stated range lies below it.
By their numbers in this assay, from the lowest: compounds 1, 2 and 3 (each within the scatter of the next); then compound 4.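

In this assay, for the compounds shown here, hydrogen in place of benzyl on a saturated ring carbon gives a number 18 percentage points higher from compound 2 to compound 4 (beyond the scatter), the only step so far. This position therefore affects the read-out, and with benzyl on this carbon compound 2 shows no inhibition at the digits printed. No measurement shown explains the step. Going by these compounds, it remains open whether an ethyl group, an amine or a carboxylic acid on the same ring carbon would keep, raise or lower this level. A single step also cannot show whether the gain carries over to other groups on the ring nitrogen.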